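This account rests on a few compounds, and the source may have more. Where it says the series, first, only, none or still open, it means among the compounds named here.

Measured in a functional assay on SW48 cells (Homo sapiens) for antiproliferative activity, read by MTT assay, with a stated time of 72 h; on this read-out lower numbers stand for stronger inhibition and higher numbers for weaker inhibition:
- compound 1 `COc1ccc([C@H]2[C@H](NC(=O)c3ccc(Cl)cc3)C(=O)N2c2cc(OC)c(OC)c(OC)c2)cc1O`: 271 nM
- compound 2 `COc1ccc([C@H]2[C@H](NC(=O)c3cc(OC)c(OC)c(OC)c3)C(=O)N2c2cc(OC)c(OC)c(OC)c2)cc1O`: 564 nM
- compound 3 `COc1ccc([C@H]2[C@H](NC(=O)c3ccc4ccccc4c3)C(=O)N2c2cc(OC)c(OC)c(OC)c2)cc1O`: 220 nM

Compound 3 cannot be separated from compound 1, as a 1.2-fold lower number from compound 1 to compound 3 (0.09 log units; within the scatter) shows. Against compound 2 the gap is real but modest: a 2.6-fold lower number from compound 2 to compound 3 (0.41 log units; beyond the scatter).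

Compound 4 `COc1ccc([C@H]2[C@H](NC(=O)C3CCCCC3)C(=O)N2c2cc(OC)c(OC)c(OC)c2)cc1O` has cyclohexyl in place of naphthalen-2-yl on a carbonyl carbon. All three measured steps are exchanges at this same place, and the other one is a 2.1-fold higher number from compound 1 to compound 2 (0.32 log units; beyond the scatter). Each of them keeps an aromatic ring there, so the data do not show how a non-aromatic ring behaves at this place. The largest of these moves, a 2.6-fold lower number from compound 2 to compound 3 (0.41 log units; beyond the scatter), sets the expected scale, and a change of that modest size is expected in this assay, towards a higher number, though with little certainty about direction. The estimated step is a 1.9-fold higher number from compound 3 to compound 4 (0.28 log units; within the scatter). Compound 4 is expected at 420 nM, with an estimated range of 170 nM to 1000 nM.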

Compound 4, half-maximal inhibitory concentration: 244 nM
Beside the measured number, compound 4's estimate is 1.7-fold (0.24 log units) above it; the range from low to high includes it.
By their numbers in this assay, from the lowest: compounds 3, 4 and 1 (each within the scatter of the next); then compound 2.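

With cyclohexyl on the carbonyl carbon, a non-aromatic ring with fewer heavy atoms sits at this place without a readable change in this assay: the results are a 1.1-fold higher number from compound 3 to compound 4 (0.04 log units; within the scatter) and a 1.1-fold lower number from compound 1 to compound 4 (0.05 log units; within the scatter), so an aromatic ring is not needed here to stay at this level. Compound 2 alone stands apart, with a 2.3-fold lower number from compound 2 to compound 4 (0.36 log units; beyond the scatter) and a 3,4,5-trimethoxyphenyl group, so aromatic character does not sort the series, since the aromatic groups of compound 1 and compound 3 stay with cyclohexyl. No measurement on hand gives a reason for these numbers.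

Going by these compounds, whether an open-chain group such as a longer chain would hold this level in place of the ring remains open. So does the effect of an amine or a carboxylic acid on a cyclohexyl ring at this place.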